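Extending the urea chain on a naphthalene sulfonamide series

The source may hold more compounds than are shown below. What is called first, only, known or untested is meant among the compounds shown, and "the series" means these compounds.

Measured compounds:
compound 1, `Cc1ccccc1C(=O)Nc1ccc(S(=O)(=O)NC2CCN(C(=O)CCN)CC2)c2ccccc12`: 11.3 nM
compound 2, `CNC(=O)N1CCC(NS(=O)(=O)c2ccc(NC(=O)c3ccccc3C)c3ccccc23)CC1`: 0.7 nM

In an assay on L1.2 cells for binding affinity to C-C chemokine receptor type 8 (Homo sapiens) (a higher number here means a weaker inhibitor, a lower number a stronger inhibitor), compound 2 stands lowest of the two numbers; the nearest is compound 1, and the change a 16-fold lower number from compound 1 to compound 2 (1.21 log units; beyond the scatter) separates them. Compound 3, `CCCNC(=O)N1CCC(NS(=O)(=O)c2ccc(NC(=O)c3ccccc3C)c3ccccc23)CC1`, differs from compound 2 by ethyl in place of hydrogen on a saturated chain carbon bound to an amide-type nitrogen, read one bond further out as methyl to propyl on the urea. Among the measured compounds shown here, no measured step concerns this kind of change; the only step, a 16-fold lower number from compound 1 to compound 2 (1.21 log units; beyond the scatter), swaps a different group on a carbonyl carbon and does not bear on it directly. Compound 3 is therefore expected to sit near compound 2, with a 1.4-fold higher number from compound 2 to compound 3 (0.15 log units; within the scatter) expected to be a small step or none beyond the scatter. The estimate for compound 3 in this assay is 1 nM, with a range from 0.3 nM to 3.5 nM.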

Compound 3, inhibition constant: 77.4 nM
For compound 3 the middle estimate is 77-fold (1.89 log units) below the measured one, outside the stated range (above it).
By their numbers in this assay, from the lowest: compound 2; then compound 1; then compound 3.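

In this assay the urea position proves far from neutral: methyl to propyl on the urea gives a 110-fold higher number from compound 2 to compound 3 (2.04 log units; beyond the scatter) and so this place responds sharply to the added ethyl. Exchanging the 2-aminoethyl group for propylamino gives a 6.8-fold higher number from compound 1 to compound 3 (0.84 log units; beyond the scatter) and so compound 3 also falls behind compound 1. No evidence at hand explains either step. The compounds shown leave open whether the loss grows gradually with chain length, and what ethylamino or cyclopropylamino in place of methylamino would give.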